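Sulfanyl to sulfonyl switch on the aryl ether chain

The compounds below may be only part of what the source reports. "The series", "measured", "known", "first", "only" and "open" are said of these compounds alone.

In an assay on RBL-2H3 cells for inhibition of Polyunsaturated fatty acid 5-lipoxygenase (Rattus norvegicus) (a higher number here means a weaker inhibitor, a lower number a stronger inhibitor), compound 2 `CCCCN(O)C(=O)Nc1cc([C@@H]2CC[C@@H](c3cc(OC)c(OC)c(OC)c3)O2)cc(OC)c1OCCSc1cccc(Br)c1` gives 43 nM, the lowest of the two numbers recorded so far. Among the measured compounds shown here, the only other measured member, compound 1 `CCCCN(O)C(=O)Nc1cc([C@@H]2CC[C@@H](c3cc(OC)c(OC)c(OC)c3)O2)cc(OC)c1OCCS(=O)(=O)c1c(F)c(F)cc(F)c1F`, gives 520 nM in this assay, a far higher number; the two differ in more than one place, so their gap is not assigned to any single change. Compound 3 `CCCCN(O)C(=O)Nc1cc([C@@H]2CC[C@@H](c3cc(OC)c(OC)c(OC)c3)O2)cc(OC)c1OCCS(=O)(=O)c1ccccc1Br` is not yet measured. It differs from compound 2 by (2-bromophenyl)sulfonyl in place of (3-bromophenyl)sulfanyl on a saturated chain carbon, two bonds along the chain from an oxygen on an aromatic ring. For the measured compounds named here, no step between measured compounds isolates this change. The expected direction in this assay is toward a higher number, since compound 1, which also carries a sulfonyl, gives 520 nM, though the aryl groups differ as well. The estimated step is a 3.7-fold higher number from compound 2 to compound 3 (0.57 log units; beyond the scatter). Compound 3 is expected to give about 160 nM, within 40 nM to 650 nM.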

Compound 3, half-maximal inhibitory concentration: 161 nM
Compound 3: middle estimate off by 1.0-fold (0.00 log units), on the low side; the range from low to high includes it.
By their numbers in this assay, from the lowest: compound 2; then compound 3; then compound 1.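

In this assay, the sulfonyl compounds now have a step of their own: a 3.2-fold lower number from compound 1 to compound 3 (0.51 log units; beyond the scatter), with 2-bromophenyl in place of 2,3,5,6-tetrafluorophenyl on a sulfonyl sulfur, so the aryl group on that sulfur affects the number. Among the compounds shown here, the a 3.7-fold higher number from compound 2 to compound 3 (0.57 log units; beyond the scatter) links the sulfanyl and sulfonyl forms for the first time, but it also carries the bromine from the 3-bromophenyl to the 2-bromophenyl arrangement, so it cannot be assigned to the sulfur change alone. Nothing available explains either step.

Going by these compounds, a (3-bromophenyl)sulfonyl group would divide the step from compound 2 into its sulfur and bromine parts, and that split remains open. Also open, on these data alone, is how a carboxylic acid on the aryl ring, or a longer chain in place of the ethyl link, would read here.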